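A few compounds are considered here, and "the series" means these few. Any claim that something is new, unique, unknown or untested is made for them only; others in the source may bear on it.

In a functional assay on A549 cells (Homo sapiens) for antiproliferative activity, read by MTT assay, with a stated time of 72 h (a higher number here means a weaker inhibitor, a lower number a stronger inhibitor), the measured compounds are:
Compound 1 `NC1=NC2(CCOCC2)N(OCCCOc2ccccc2)C(N)=N1` gives 1080 nM
Compound 2 `NC1=NC2(CCOCC2)N(OCCCOc2ccc(Cl)cc2)C(N)=N1` gives 360 nM
Compound 3 `NC1=NC2(CCOCC2)N(OCCCOc2ccc(F)cc2)C(N)=N1` gives 1060 nM

Compound 3, with its 4-fluorophenyl group, sits within the scatter of compound 1 (a 1.0-fold lower number from compound 1 to compound 3 (0.01 log units; within the scatter)), while compound 2 stands apart from it (a 2.9-fold higher number from compound 2 to compound 3 (0.47 log units; beyond the scatter)). Compound 4 `Cc1cc(C)cc(OCCCON2C(N)=NC(N)=NC23CCOCC3)c1` keeps the shared core and the chain and differs in one place (3,5-dimethylphenyl in place of 4-fluorophenyl on an oxygen on a saturated carbon): 3,5-dimethylphenyl in place of 4-fluorophenyl on an oxygen on a saturated carbon. Among the measured compounds shown here, no measured compound carries methyl groups, so the measured steps bear on this change only indirectly. Changes on this aromatic ring have so far been modest or absent, with chloro in place of hydrogen giving a modest step (a 3.0-fold lower number from compound 1 to compound 2 (0.48 log units; beyond the scatter)) and fluoro in place of hydrogen giving none beyond the scatter. A small move toward a lower number in this assay is therefore expected, most likely not beyond the scatter. The estimated step is the following (a 1.5-fold lower number from compound 3 to compound 4 (0.18 log units; within the scatter)). For compound 4 the estimated value is 700 nM, with an expected range from 280 nM to 1600 nM as its limits.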

Compound 4, half-maximal inhibitory concentration: 710 nM
For compound 4 the middle estimate is 1.0-fold (0.01 log units) below the measured one, and the stated range covers the measured number.
By their numbers in this assay, from the lowest: compounds 2, 4, 3 and 1 (each within the scatter of the next, the first and the last beyond it).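

In this assay, the 3,5-dimethylphenyl group, the only ring here with two substituents and with no halogen or a bare ring as its comparison, lies within the scatter of all three other rings (a 1.5-fold lower number from compound 3 to compound 4 (0.17 log units; within the scatter)) (a 1.5-fold lower number from compound 1 to compound 4 (0.18 log units; within the scatter)) (a 2.0-fold higher number from compound 2 to compound 4 (0.29 log units; within the scatter)). Among the compounds shown here, this position on the oxygen therefore accepts two methyl groups on the ring with no step beyond the scatter, whereas the earlier compounds showed only single substitutions, one of which, chloro, gave a step beyond it. Compound 4 does not side with compound 2 or with compound 1, and no measurement at hand offers an explanation for this result. From the compounds shown here alone, it remains open what a single methyl group, or a ring with two chloro groups, would give. Going by these compounds, an amine or a carboxylic acid on the ring, or a longer chain to the shared core, is equally open.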